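A few compounds are considered here, and "the series" means these few. Any claim that something is new, unique, unknown or untested is made for them only; others in the source may bear on it.

Three compounds built on a shared quinone-type core with a selenium-linked side chain have been tested in an ADME assay on HUVEC cells (Homo sapiens) for cytotoxicity, read by MTT assay, with a stated time of 24 h; on this read-out higher numbers stand for weaker inhibition and lower numbers for stronger inhibition. Compound 1 `CC1=C([Se]CC(OC(=O)[C@@H](CO)NC(=O)OC(C)(C)C)C(=O)NC(C)(C)C)C(=O)c2ccccc2C1=O` gives 3000 nM. Compound 2 `CC1=C([Se]CC(OC(=O)[C@@H](CO)NC(=O)OC(C)(C)C)C(=O)NCCCCCC(=O)OCc2ccccc2)C(=O)c2ccccc2C1=O` gives 35000 nM. Compound 3 `CC1=C([Se]CC(OC(=O)CNC(=O)OC(C)(C)C)C(=O)NCCCCCC(=O)OCc2ccccc2)C(=O)c2ccccc2C1=O` gives 36000 nM. Among these, compound 3 and compound 2 lie within the scatter of each other, while compound 1 stands well below both, beyond the scatter. Going by the values given here, the only measured step, a 1.0-fold higher number from compound 2 to compound 3 (0.01 log units; within the scatter), concerns a different exchange and offers no guide to the change now considered. Compound 4 `CC1=C([Se]CC(OC(=O)CC[Se]c2ccccc2)C(=O)NCCCCCC(=O)OCc2ccccc2)C(=O)c2ccccc2C1=O` differs from compound 3 by a group of 8 heavy atoms (7 carbon, 1 selenium; one six-membered aromatic ring of carbon only) in place of a group of 8 heavy atoms (5 carbon, 1 nitrogen, 2 oxygen; no ring), on a saturated chain carbon bound to a carbonyl carbon. Among the compounds with values here, no measured step bears on an exchange of this kind, so the expectation rests on compound 3 alone and carries a wide margin. The step from compound 3 to compound 4 is expected to be a 1.2-fold lower number from compound 3 to compound 4 (0.08 log units; within the scatter), that is, no change beyond the scatter in either direction. Compound 4 is therefore estimated at 30000 nM, with a range from 8000 nM to 100000 nM.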

Compound 4, half-maximal inhibitory concentration: 3000 nM
Compound 4: middle estimate off by 10-fold (1.00 log units), on the high side, outside the stated range (below it).
By their numbers in this assay, from the lowest: compounds 1 and 4 (each within the scatter of the next); then compounds 2 and 3 (each within the scatter of the next).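

In this assay, the saturated chain carbon bound to a carbonyl carbon proves sensitive to what it carries: the selenium-bearing aromatic group in place of (tert-butoxycarbonyl)amino gives a 12-fold lower number from compound 3 to compound 4 (1.08 log units; beyond the scatter), which means stronger inhibition. The wider exchange on the carbonyl carbon gives much the same result, a 12-fold lower number from compound 2 to compound 4 (1.07 log units; beyond the scatter), whereas losing only the hydroxymethyl group gave a 1.0-fold higher number from compound 2 to compound 3 (0.01 log units; within the scatter), so the large drop appears only when (tert-butoxycarbonyl)amino is replaced. Nothing available explains this drop.

The entering group differs from the one it replaces in both its selenium and its aromatic ring, so the compounds shown cannot separate the two. A plain phenyl group or a free amine on this carbon would be needed to tell which part goes with the lower number.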